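Replacing 1,3-thiazol-2-yl with 3-chlorophenyl in compound 2

The source may hold more compounds than are shown below. What is called first, only, known or untested is meant among the compounds shown, and "the series" means these compounds.

Compound 1 `Cc1ccc(NC(=O)Nc2cccc(-c3cccc4[nH]nc(N)c34)c2)cc1` gives 4450 nM
Compound 2 `Nc1n[nH]c2cccc(-c3cccc(NC(=O)Nc4nccs4)c3)c12` gives 550 nM

In a functional assay on SMMC-7721 cells (Homo sapiens) for inhibition, read by MTT assay, with a stated time of 48 h (on this read-out higher numbers stand for weaker inhibition and lower numbers for stronger inhibition), compound 2 has the lower of the two numbers (550 nM). Compound 3 `Nc1n[nH]c2cccc(-c3cccc(NC(=O)Nc4cccc(Cl)c4)c3)c12` carries 3-chlorophenyl in place of 1,3-thiazol-2-yl on an amide-type nitrogen. For the measured compounds named here, the only measured step that bears on this is the swap of 4-methylphenyl for 1,3-thiazol-2-yl at that nitrogen (an 8.1-fold lower number from compound 1 to compound 2 (0.91 log units; beyond the scatter)). Compound 3 returns to a six-membered aromatic ring of carbon only, as in compound 1 (4450 nM), so a similar step in reverse, towards weaker inhibition, is expected (a 5.1-fold higher number from compound 2 to compound 3 (0.71 log units; beyond the scatter)). The estimated value for compound 3 is 2800 nM (expected range 800 nM to 9000 nM).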

Compound 3, half-maximal inhibitory concentration: 1830 nM
The estimate for compound 3 lay 1.5-fold (0.18 log units) above the measured number; measured number inside the range.
By their numbers in this assay, from the lowest: compound 2; then compound 3; then compound 1.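

In this assay, moving from 1,3-thiazol-2-yl to a carbon-only ring does weaken inhibition, with a 3.3-fold higher number from compound 2 to compound 3 (0.52 log units; beyond the scatter), yet 3-chlorophenyl still outperforms 4-methylphenyl, with a 2.4-fold lower number from compound 1 to compound 3 (0.39 log units; beyond the scatter). At this nitrogen, then, the number depends on the groups carried by the six-membered ring as well as on the ring type, and 1,3-thiazol-2-yl gives the lowest number of the three. Nothing available explains these differences.

The compounds shown leave open how an unsubstituted phenyl would compare, and whether a pyridin-2-yl ring would behave more like 1,3-thiazol-2-yl or like the phenyl groups.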